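Replacing a Chlorinated Aroyl Group in a Dibenzoylhydrazine Series

The source may hold more compounds than are shown below. What is called first, only, known or untested is meant among the compounds shown, and "the series" means these compounds.

Measured so far:
compound 1 `CC(C)(C)N(NC(=O)c1ccccc1)C(=O)c1ccccc1Br` 170 nM
compound 2 `CCc1ccccc1C(=O)N(NC(=O)c1ccccc1)C(C)(C)C` 589 nM
compound 3 `CC(C)(C)N(NC(=O)c1ccccc1Cl)C(=O)c1ccccc1Cl` 331 nM

In an assay on cells for agonist activity at ecdysone receptor (Bombyx mori), read by a luciferase reporter, with a stated time of 24 h (on this read-out higher numbers stand for an effect only at larger amounts of compound and lower numbers for an effect already at smaller amounts), compound 3 stands second highest of the three numbers; it sits within the scatter of both compound 1 and compound 2. Compound 4 `Cc1cccc(C(=O)NN(C(=O)c2ccccc2Cl)C(C)(C)C)c1` differs from compound 3 by 3-methylphenyl in place of 2-chlorophenyl on a carbonyl carbon. Within the data shown here, no measured step touches this position: the only step, a 3.5-fold higher number from compound 1 to compound 2 (0.54 log units; beyond the scatter), concerns the other ring and was modest. Compound 1 and compound 3 differ at the same place as the present change, yet their values lie within the scatter of one another, so little movement is expected. For compound 4 a slightly lower number is estimated, a 1.8-fold lower number from compound 3 to compound 4 (0.26 log units; within the scatter), giving 180 nM with a range from 50 nM to 650 nM.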

Compound 4, half-maximal effective concentration: 603 nM
Compound 4: middle estimate off by 3.4-fold (0.53 log units), on the low side, within the range that was stated.
By their numbers in this assay, from the lowest: compounds 1, 3, 2 and 4 (each within the scatter of the next, the first and the last beyond it).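

In this assay, 3-methylphenyl in place of 2-chlorophenyl on a carbonyl carbon gives a 1.8-fold higher number from compound 3 to compound 4 (0.26 log units; within the scatter), the first step read at this position. Compound 4 lacks the chlorine on this ring, yet stays within the scatter of compound 3, so this ring need not carry that chlorine for a number of this order. Nothing available explains the result.

The identity of the group and its place on the ring change together in this step, and the compounds shown do not separate the two. From the compounds shown here alone, how an amine or a carboxylic acid on this ring would read remains open.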